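This account rests on a few compounds, and the source may have more. Where it says the series, first, only, none or still open, it means among the compounds named here.

Measured so far:
- compound 1, `O=C(NCCO)c1c(O)c2ncc(Cc3ccc(F)cc3)cc2[nH]c1=O`: 3060 ng.h/mL
- compound 2, `COCCNC(=O)c1c(O)c2ncc(Cc3ccc(F)cc3)cc2n(C)c1=O`: 1850 ng.h/mL

In an ADME assay on the whole organism (plasma, strain CD) for pharmacokinetics, with Rattus norvegicus as the target, at a dose of 5 mg/kg by the oral route (a lower number here means less compound in the circulation, a higher number more compound in the circulation at the dose given), compound 1 gives 3060 ng.h/mL, and compound 2 gives 1850 ng.h/mL. Compound 1 has the higher of the two numbers, yet the gap to compound 2 lies within the usual scatter, so the two cannot really be told apart. Compound 3, `C[C@H](CO)NC(=O)c1c(O)c2ncc(Cc3ccc(F)cc3)cc2[nH]c1=O`, has not been measured. It differs from compound 1 by methyl in place of hydrogen on a saturated chain carbon bound to an amide-type nitrogen and a saturated chain carbon. Nothing measured here shows how such a change moves exposure. The step of a 1.2-fold lower number from compound 1 to compound 3 (0.09 log units; within the scatter) is expected to be small, not beyond the scatter. For compound 3 the expected value is 2500 ng.h/mL, in the range 1000 ng.h/mL to 6000 ng.h/mL.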

Compound 3, area under the concentration-time curve: 6370 ng.h/mL
The estimate for compound 3 lay 2.5-fold (0.41 log units) below the measured number, and the stated range ends below it.
By their numbers in this assay, from the lowest: compounds 2 and 1 (each within the scatter of the next); then compound 3.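

In this assay methyl in place of hydrogen on this saturated chain carbon gives a 2.1-fold higher number from compound 1 to compound 3 (0.32 log units; beyond the scatter) and so shows that exposure responds to a single added carbon at this position. This is the first change in one place among the compounds shown, so it is the first direct reading of any one group's link to exposure. No measurement here gives a reason for the rise. Still open, going by these compounds, is whether ethyl in place of this methyl, or the mirror-image form of compound 3, would match it. On these data alone, whether an amine in place of the chain's hydroxyl would keep the higher exposure is also open.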